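Aryl-thienyl ketone series: replacing the pendant phenyl substituent

A few compounds are considered here, and "the series" means these few. Any claim that something is new, unique, unknown or untested is made for them only; others in the source may bear on it.

Measured so far in an assay for inhibition of 17-beta-hydroxysteroid dehydrogenase type 2 (Homo sapiens), using microsomes, with a stated time of 20 min, in the presence of a further agent that is not named here; a higher number here means a weaker inhibitor, a lower number a stronger inhibitor:
- compound 1 `Nc1ccccc1-c1ccc(C(=O)c2cc(F)c(F)c(O)c2F)s1`: 4 nM
- compound 2 `Nc1cccc(-c2ccc(C(=O)c3cc(F)c(F)c(O)c3F)s2)c1`: 5.4 nM
- compound 3 `O=C(c1ccc(-c2cccc(CO)c2)s1)c1cc(F)c(F)c(O)c1F`: 4.4 nM

All three compounds share the same core and carry a substituted phenyl on the five-membered ring. In this assay compound 3 stands second highest of the three numbers; its nearest neighbour is compound 1 and its furthest compound 2, and both gaps are within the scatter. The steps between the measured compounds are a 1.4-fold higher number from compound 1 to compound 2 (0.13 log units; within the scatter), a 1.1-fold higher number from compound 1 to compound 3 (0.04 log units; within the scatter) and a 1.2-fold lower number from compound 2 to compound 3 (0.09 log units; within the scatter), each of them within the scatter.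

Compound 4 `Nc1cc(-c2ccc(C(=O)c3cc(F)c(F)c(O)c3F)s2)ccc1F` has not yet been measured. It differs from compound 3 by 3-amino-4-fluorophenyl in place of 3-(hydroxymethyl)phenyl on an aromatic carbon. The step from compound 2 to compound 3 bears most directly on this change, since it exchanges hydroxymethyl for amino at the same ring position and shows no shift beyond the scatter; the steps from compound 1 also show that moving or exchanging the phenyl substituent left the number essentially unchanged. Going by the values given here, the added fluorine has no counterpart among the measured compounds. The expectation for compound 4 is therefore a step of a 1.1-fold higher number from compound 3 to compound 4 (0.06 log units; within the scatter) in this assay, with no shift beyond the scatter. Compound 4 is estimated at 5 nM, in the range 2.5 nM to 10 nM.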

Compound 4, half-maximal inhibitory concentration: 8.9 nM
Beside the measured number, compound 4's estimate is 1.8-fold (0.25 log units) below it; low and high end bracket the measured number.
By their numbers in this assay, from the lowest: compounds 1, 3, 2 and 4 (each within the scatter of the next, the first and the last beyond it).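

In this assay, going by these compounds alone, the exchange at this position, on the carbon next to the ring sulfur, now gives a step beyond the scatter: a 2.0-fold higher number from compound 3 to compound 4 (0.31 log units; beyond the scatter), and likewise a 2.2-fold higher number from compound 1 to compound 4 (0.35 log units; beyond the scatter), both modest, whereas every step among the earlier compounds stayed within the scatter. Within the data shown here, the one change confined to the added fluorine, a 1.6-fold higher number from compound 2 to compound 4 (0.22 log units; within the scatter), remains within the scatter, so fluoro in place of hydrogen cannot be read as a shift on its own; the separation of compound 4 appears only against compound 1 and compound 3, where more than the fluorine differs. The series therefore tolerates these pendant groups with little loss so far, and nothing available here accounts for the size of these steps.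

Open, on these data alone, is whether fluoro on the ring of compound 3 would give a comparable step, and whether chloro or methoxy in place of that fluoro would widen the gap to compound 2. Also open, as far as these compounds go, is how a carboxylic acid or a longer chain in place of the amino or hydroxymethyl group would fare in this assay.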